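This account rests on a few compounds, and the source may have more. Where it says the series, first, only, none or still open, it means among the compounds named here.

The compounds measured so far:

Compound 1, `CN(C)c1cc2[nH]c(C3CCCCC3)nc2cc1NC(=O)c1ccc(Br)cc1`: in an ADME assay on Vero cells (Chlorocebus sabaeus) for cytotoxicity, read by resazurin assay, with a stated time of 3 days (a higher number here means a weaker inhibitor, a lower number a stronger inhibitor), compound 1 gives > 100 ug/mL, which is a limit of the assay rather than a number.
Compound 2, `CCN(CC)c1cc2[nH]c(C3CCCCC3)nc2cc1NC(=O)c1ccc(OC(F)F)cc1`: compound 2 gives > 100 ug/mL, again a limit.
Compound 3, `CCCCOC(=O)Nc1cc2nc(C3CCCCC3)[nH]c2cc1N(CC)CC`: compound 3 gives > 100 ug/mL, also a limit.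

Compound 3 therefore stands only at a limit, as do the other two values shown, so nothing places it above or below them; all three sit at the limit of > 100 ug/mL in this assay, at which 3 of the 3 values shown sit. Going by the values given here, the one step within the measured set, a step that the two limits leave unreadable from compound 2 to compound 3, is left unreadable by the two limits, so it gives no size.

Compound 4, `CCN(CC)c1cc2[nH]c(C3CCCCC3)nc2cc1NC(=O)c1ccc(Br)cc1`, differs from compound 3 by 4-bromophenyl in place of butoxy on a carbonyl carbon. Compound 1 carries the same 4-bromophenyl on its carbonyl carbon and reaches only a limit, and compound 3 reaches only a limit, so the measured values offer no readable step for this change in either direction. Nothing beyond the scatter is expected in this assay.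

Compound 4 is therefore expected to give 150 ug/mL, with a range from 60 ug/mL to 400 ug/mL. The step this estimate implies, a step that the limit leaves unreadable from compound 3 to compound 4, is expected to be nothing beyond the scatter, and the assay is most likely to report only a limit.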

Compound 4, half-maximal inhibitory concentration: > 100 ug/mL
Compound 4: only a limit was reported (the forecaster's own chance of this, stated with the estimate: 85%); the middle value does not contradict the limit.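

In this assay compound 4 gives > 100 ug/mL, which is a limit of the assay and not a number. No new step can be read from compound 4 to compound 1, compound 2 or compound 3, since all of them stand at the same point: the limit of > 100 ug/mL in this assay, at which 4 of the 4 values shown sit.

The compounds shown leave open whether any of these changes shifts the read-out in this assay at all.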